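Inverting Both Stereocentres of Compound 2

This account rests on a few compounds, and the source may have more. Where it says the series, first, only, none or still open, it means among the compounds named here.

Of the compounds shown here, two built on a shared core have so far been measured in a functional assay on HEK293 cells for agonist activity at Neuronal acetylcholine receptor; alpha4/beta2 (Homo sapiens), read by FLIPR; on this read-out lower numbers stand for an effect already at smaller amounts and higher numbers for an effect only at larger amounts of compound. Compound 1 `Clc1cc(N2CC[C@@H]3CN[C@@H]3C2)cnc1Cl` gives 82 nM in this assay. Compound 2 `Cc1cc(N2CC[C@H]3CN[C@H]3C2)cnc1Cl` gives 7.2 nM in this assay, which is the lowest of the two numbers; its nearest neighbour is compound 1, whose number stands clearly higher, beyond the scatter of repeated measurements.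

Compound 3 `Cc1cc(N2CC[C@@H]3CN[C@@H]3C2)cnc1Cl` has not yet been measured in this assay. Set against compound 2, (the two compounds have the same atoms and bonds and differ only in configuration as drawn: 2 of 2 stereo elements differ (all stereocentres are inverted: mirror images); a stereocentre at a saturated ring carbon is drawn S in compound 2 and R in compound 3; a stereocentre at a saturated ring carbon is drawn R in compound 2 and S in compound 3). Among the measured compounds there is no pair that differs only in this way, so the size of such a step has not been observed here. Since compound 2 holds the lowest number seen, and a full inversion of configuration commonly separates two mirror images widely in this assay, the more probable direction for compound 3 is upward, though a step within the scatter cannot be ruled out. Compound 3 is therefore expected to give about 70 nM in this assay, within a range from 7 nM to 700 nM, a step from compound 2 to compound 3 estimated as a 9.7-fold higher number from compound 2 to compound 3 (0.99 log units; beyond the scatter).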

Compound 3, half-maximal effective concentration: 47 nM
The estimate for compound 3 lay 1.5-fold (0.17 log units) above the measured number; the range from low to high includes it.
By their numbers in this assay, from the lowest: compound 2; then compounds 3 and 1 (each within the scatter of the next).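

In this assay, inverting both stereocentres gives a 6.5-fold higher number from compound 2 to compound 3 (0.81 log units; beyond the scatter), the first size seen in this series for a step that changes nothing but the configuration as drawn. Within the configuration shared by compound 1 and compound 3, methyl in place of chloro on an aromatic carbon gives a 1.7-fold lower number from compound 1 to compound 3 (0.24 log units; within the scatter), so this read-out does not separate the two groups in that configuration, whereas the inversion moves the number beyond the scatter. The step from compound 2 to compound 3 can be assigned to configuration alone because no atom or bond separates the pair: the fact that compounds 2 and 3 differ only in the configuration as drawn

The compounds shown leave open how chloro would read in the configuration of compound 2, and so whether the gain seen with that configuration extends beyond the methyl compounds. They also leave open which of the two stereocentres carries the step, since both change together here, and how a group such as a methoxy, a nitrile or an amine in place of methyl on the aromatic carbon would read in either configuration.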